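Aryl amine exchange on the pyrrole-fused core: cytotoxicity notes

The compounds below may be only part of what the source reports. "The series", "measured", "known", "first", "only" and "open" are said of these compounds alone.

Two members of the series have a cytotoxicity reading. Compound 1 `N#C/C=C/c1cc(F)c(Oc2nc(Nc3ccc(C#N)nc3)nc3ccsc23)c(F)c1` gives 47500 nM in a toxicity assay on MT4 cells (Homo sapiens) for cytotoxicity, read by MTT assay, with a stated time of 5 days; on this read-out higher numbers stand for lower toxicity in this test and lower numbers for higher toxicity in this test. Compound 2 `N#C/C=C/c1cc(F)c(Oc2nc(Nc3ccc(C#N)c(F)c3)nc3cc[nH]c23)c(F)c1` gives 10200 nM in this assay, the lowest of the two numbers; compound 1 stands at a higher number, beyond the scatter. Among the measured compounds shown here, the two differ in two places, so no single step connects them.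

Compound 3 `N#C/C=C/c1cc(F)c(Oc2nc(Nc3ccc(C#N)nc3)nc3cc[nH]c23)c(F)c1` carries 6-cyanopyridin-3-yl in place of 4-cyano-3-fluorophenyl on a nitrogen on an aromatic ring. This is the same amine as in compound 1, but on the core of compound 2. For the measured compounds named here, with no matched step in hand, the expectation leans on compound 1 and its 47500 nM and on compound 2 and its 10200 nM: a modest move toward a higher number is expected, possibly within the scatter. The expected step is a 2.0-fold higher number from compound 2 to compound 3 (0.29 log units; within the scatter). Compound 3 is estimated at 20000 nM in this assay, with a range of 7000 nM to 60000 nM.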

Compound 3, half-maximal cytotoxic concentration: 29000 nM
For compound 3 the middle estimate is 1.5-fold (0.16 log units) below the measured one, and the stated range covers the measured number.
By their numbers in this assay, from the lowest: compound 2; then compounds 3 and 1 (each within the scatter of the next).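

In this assay the exchange of 4-cyano-3-fluorophenyl for 6-cyanopyridin-3-yl on a nitrogen on an aromatic ring can now be read as a single change, with a 2.8-fold higher number from compound 2 to compound 3 (0.45 log units; beyond the scatter) as a modest step. Among the compounds shown here, the earlier pair differed in two places, so this is the first reading of the amine change alone on one core. Compound 3 and compound 1 carry the same amine on different cores and lie within the scatter of each other, so with this amine the two cores are not told apart on these numbers.

As far as these compounds go, whether a carboxylic acid or a methoxy group in place of the nitrile would move the number stays open, as does the same exchange on the core of compound 1. Nothing at hand bears on why this step has its size.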